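This account rests on a few compounds, and the source may have more. Where it says the series, first, only, none or still open, it means among the compounds named here.

Measured compounds:
- Compound 1, `COc1ccc2c(c1)c(/C=N\NC(=O)c1c[nH]c3ccc(Br)cc13)cn2Cc1ccc(Cl)cc1`: in a functional assay on MIA PaCa-2 cells (Homo sapiens) for cytotoxicity (on this read-out lower numbers stand for stronger inhibition and higher numbers for weaker inhibition), compound 1 gives 26300 nM.
- Compound 2, `O=C(N/N=C\c1cn(Cc2ccc(Cl)cc2)c2cc(F)ccc12)c1c[nH]c2ccccc12`: in this assay compound 2 gives 18000 nM.

The two numbers lie close together. The gap between compound 1 and compound 2 is within the usual scatter of repeated measurements of this kind, so on this evidence neither can be called stronger or weaker than the other; both sit in a weak range. Compound 2 is the starting point for the next step. Compound 3, `Cn1cc(C(=O)N/N=C\c2cn(Cc3ccc(Cl)cc3)c3cc(F)ccc23)c2ccccc21`, has not yet been tested. Its difference from compound 2 is methyl in place of hydrogen on an aromatic nitrogen; cut one bond further out, the same difference reads 1H-indol-3-yl to 1-methyl-1H-indol-3-yl. For the measured compounds named here, no measured pair among the tested compounds shows what such a change does, so the expectation rests on the structural change alone, which is small in size. The step of a 1.1-fold higher number from compound 2 to compound 3 (0.05 log units; within the scatter) is expected to stay within the scatter, with no clear direction either way. Compound 3 is therefore estimated to give 20000 nM, with a likely range from 7000 nM to 60000 nM.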

Compound 3, half-maximal inhibitory concentration: 50400 nM
Beside the measured number, compound 3's estimate is 2.5-fold (0.40 log units) below it; the measured number falls inside the stated range.
By their numbers in this assay, from the lowest: compounds 2, 1 and 3 (each within the scatter of the next, the first and the last beyond it).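

In this assay, for the compounds shown here, changing 1H-indol-3-yl to 1-methyl-1H-indol-3-yl gives a 2.8-fold higher number from compound 2 to compound 3 (0.45 log units; beyond the scatter), and this is the first pair of compounds here that differ in one place only. This position on the aromatic nitrogen is therefore not neutral: adding a single carbon there moves the result beyond the scatter, modestly and towards weaker inhibition, although compound 2 was itself already in a weak range. The change both adds a methyl and removes the hydrogen on that nitrogen, so this one pair cannot show which of the two matters, and no measurement available here explains the step.

Going by these compounds, it remains open whether a larger group on the same nitrogen, such as ethyl or a longer chain ending in an amine or a carboxylic acid, would weaken inhibition further or reverse the trend. On these data alone, it is also open whether the same methyl would have a similar effect on another member of the series, such as compound 1, whose other substituents differ from those of compound 2.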